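Lengthening the Carbamate Ester Chain in Two Related Series

A few compounds are considered here, and "the series" means these few. Any claim that something is new, unique, unknown or untested is made for them only; others in the source may bear on it.

Compound 1, `CCOC(=O)N1N=C(c2cccc(OC)c2)CC1c1cc(OC)c(OC)c(OC)c1`, gives 5920 nM in a functional assay on A549 cells (Homo sapiens) for antiproliferative activity, read by MTT assay, with a stated time of 48 h; a higher number here means a weaker inhibitor of growth, a lower number a stronger inhibitor of growth.
Compound 2, `CCCOC(=O)N1N=C(c2cccc(OC)c2)CC1c1cc(OC)c(OC)c(OC)c1`, reaches only a limit in this assay, namely > 10000 nM.
Compound 3, `COC(=O)N1N=C(c2ccc(OC)cc2)CC1c1cc(OC)c(OC)c(OC)c1`, gives 3400 nM in this assay.

Compounds 1 and 2 share one core, and the change between them is methyl in place of hydrogen on a saturated chain carbon, two bonds along the chain from an oxygen next to a carbonyl group. The measured step is an at least 1.6-fold higher number from compound 1 to compound 2 (0.22 log units; that floor lies within the scatter). Going by these compounds, its true size stays open, since compound 2 sits at the limit of > 10000 nM in this assay, at which 1 of the 3 values shown sits.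

Compound 3 carries a different core, and the difference between the two cores is not broken down here. Its number and that of compound 1 lie within the usual scatter of each other, so no order between them can be read from these two values.

Compound 4, `CCOC(=O)N1N=C(c2ccc(OC)cc2)CC1c1cc(OC)c(OC)c(OC)c1`, has not yet been measured. It differs from compound 3 by methyl in place of hydrogen on a saturated chain carbon bound to an oxygen next to a carbonyl group. Within the data shown here, this is the same kind of change as the one from compound 1 to compound 2, but the place is not the same: here the carbon is bound to an oxygen next to a carbonyl group, whereas in the earlier pair it lies two bonds along the chain from an oxygen next to a carbonyl group. Among the measured compounds shown here, a step of similar direction and modest size is expected, a 1.6-fold higher number from compound 3 to compound 4 (0.21 log units; within the scatter), resting on an at least 1.6-fold higher number from compound 1 to compound 2 (0.22 log units; that floor lies within the scatter) as the only chain-lengthening step measured so far. Compound 4 is therefore estimated at 5500 nM, with the expectation spanning from 2500 nM to 12000 nM.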

Compound 4, concentration for 50% growth inhibition: 4690 nM
The estimate for compound 4 lay 1.2-fold (0.07 log units) above the measured number, and the stated range covers the measured number.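

In this assay, methyl in place of hydrogen on the core of compound 3 gives a 1.4-fold higher number from compound 3 to compound 4 (0.14 log units; within the scatter), and 4-methoxyphenyl in place of 3-methoxyphenyl gives a 1.3-fold lower number from compound 1 to compound 4 (0.10 log units; within the scatter), so neither change separates the compounds it links. The methyl change has now been read on two cores, though the added carbon does not sit at the same place on the ester chain in the two pairs: the same change on two cores in this assay, an at least 1.6-fold higher number (0.22 log units; that floor lies within the scatter) from compound 1 to compound 2 and a 1.4-fold higher number (0.14 log units; within the scatter) from compound 3 to compound 4; the limit leaves it open whether they differ. Among these compounds, this does not show that the change carries over from one core to the other with the same size, nor that it weakens growth inhibition on either core, and the one step that might speak to this ends at a limit rather than a number: the limit of > 10000 nM in this assay, at which 1 of the 4 values shown sits.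

The compounds shown leave open how a butyl ester or a longer chain would read on either core, and whether the step seen so far would then grow beyond the scatter. They also leave open how an amide or a carboxylic acid in place of the carbamate ester would read, as every compound here carries that ester.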